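Adding a second fluoro to compound 3

The source may hold more compounds than are shown below. What is called first, only, known or untested is meant among the compounds shown, and "the series" means these compounds.

Compound 1 `Cc1csc(-c2cc(C)c(Nc3ccnc(Nc4ccc(C#N)cc4)n3)c(C)c2)c1`: 34000 nM
Compound 2 `Cc1ccc(-c2cc(C)c(Nc3ccnc(Nc4ccc(C#N)cc4)n3)c(C)c2)s1`: 28000 nM
Compound 3 `Cc1cc(-c2ccnc(F)c2)cc(C)c1Nc1ccnc(Nc2ccc(C#N)cc2)n1`: 6000 nM

In a toxicity assay on MT4 cells (Homo sapiens) for cytotoxicity, read by MTT assay, with a stated time of 5 days (a lower number here means that less compound is tolerated, a higher number that more compound is tolerated), compound 3 stands lowest of the three at 6000 nM, and its steps to both others lie beyond the scatter. The other two do not separate, with a 1.2-fold lower number from compound 1 to compound 2 (0.08 log units; within the scatter).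

The next compound is compound 4 `Cc1cc(-c2cc(F)nc(F)c2)cc(C)c1Nc1ccnc(Nc2ccc(C#N)cc2)n1`. It differs from compound 3 by fluoro in place of hydrogen on an aromatic carbon, turning 2-fluoropyridin-4-yl into 2,6-difluoropyridin-4-yl: fluoro in place of hydrogen on an aromatic carbon.

For the measured compounds named here, no measured pair isolates this change. The nearest evidence comes from the two steps that exchange a methylthiophene group for the 2-fluoropyridin-4-yl group: a 5.7-fold lower number from compound 1 to compound 3 (0.75 log units; beyond the scatter), and a 4.7-fold lower number from compound 2 to compound 3 (0.67 log units; beyond the scatter). Both are modest, and both replace an entire ring substituent rather than a single hydrogen. With so small a change, a step smaller than these is expected in this assay, probably none beyond the scatter, and the data give no firm direction. The expected change is a 1.2-fold higher number from compound 3 to compound 4 (0.07 log units; within the scatter). The estimate for compound 4 is 7000 nM, with an expected range from 2500 nM to 20000 nM.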

Compound 4, half-maximal cytotoxic concentration: 6300 nM
The estimate for compound 4 lay 1.1-fold (0.05 log units) above the measured number; measured number inside the range.
By their numbers in this assay, from the lowest: compounds 3 and 4 (each within the scatter of the next); then compounds 2 and 1 (each within the scatter of the next).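

In this assay, for the compounds shown here, the second fluoro, placed next to the ring nitrogen and meta to the first fluoro group, gives the first reading of a single-atom change on this ring: a 1.1-fold higher number from compound 3 to compound 4 (0.02 log units; within the scatter), so compound 3 and compound 4 do not separate. The separation from the methylthiophene compounds therefore holds with the 2,6-difluoropyridin-4-yl group as it did with the 2-fluoropyridin-4-yl group, with a 4.4-fold lower number from compound 2 to compound 4 (0.65 log units; beyond the scatter) and a 5.4-fold lower number from compound 1 to compound 4 (0.73 log units; beyond the scatter), and among these four compounds the two fluoropyridines stand together, apart from the two methylthiophenes. Nothing measured here accounts for either the lack of separation or the gap to the methylthiophene compounds.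

The compounds shown leave open whether this place tolerates anything other than hydrogen and fluoro, since a chloro, a methoxy or an amine there might or might not stay level with compound 3. They also leave open whether the fluoro already present in compound 3 matters at all, a question that a plain pyridin-4-yl group carrying no fluoro would address.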